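Swapping One Arm of a Low-Toxicity Compound

This account rests on a few compounds, and the source may have more. Where it says the series, first, only, none or still open, it means among the compounds named here.

- Compound 1 `COc1cc(-c2nn(-c3cccc(NC(=O)Nc4ccc(Cl)c(Cl)c4)c3)cc2-c2ccncc2)ccc1Cl`: > 50000 nM
- Compound 2 `O=C(Nc1cccc(-n2cc(-c3ccncc3)c(-c3ccc(Cl)c(O)c3)n2)c1)Nc1ccc(Cl)c(Cl)c1`: > 32500 nM

In a functional assay on Malme-3M cells (Homo sapiens) for inhibition, read by sulforhodamine B assay, with a stated time of 48 h (on this read-out higher numbers stand for lower toxicity in this test and lower numbers for higher toxicity in this test), compound 1 gives > 50000 nM, and this is a limit and not a number. Compound 2 gives > 32500 nM, which is also a limit. Compound 1 therefore has no exact position on this scale, and only its limit can serve as the starting point.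

Compound 3 `COc1cc(-c2nn(-c3cccc(NC(=O)c4ccc(Cl)c(C(F)(F)F)c4)c3)cc2-c2ccncc2)ccc1Cl` has not yet been measured. It differs from compound 1 by 4-chloro-3-(trifluoromethyl)phenyl in place of (3,4-dichlorophenyl)amino on a carbonyl carbon, with 4-chloro-3-(trifluoromethyl)phenyl in place of (3,4-dichlorophenyl)amino on a carbonyl carbon.

Going by the values given here, only one measured step is available, a step that the two limits leave unreadable from compound 1 to compound 2, and it offers little guidance. That change is hydrogen in place of methyl on an oxygen on an aromatic ring, which is not the change made here. No measured size or direction therefore carries over, so no shift beyond the usual scatter is expected. The estimated change is an at least 1.1-fold lower number from compound 1 to compound 3 (0.04 log units; that floor lies within the scatter). In this assay, compound 3 is expected to give about 45000 nM, within an estimated range of 15000 nM to 100000 nM.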

Compound 3, concentration lethal to 50% of the cells: > 32500 nM
Compound 3 gave a limit, no number; the forecaster's own chance of this, stated with the estimate: 65%; the middle value does not contradict the limit.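

In this assay compound 3 gives > 32500 nM, which is a limit and not a number. Compound 1 and compound 3 both stand only as limits, and the step between them cannot be read. The compounds shown leave open where any of them truly sits, and whether 4-chloro-3-(trifluoromethyl)phenyl in place of (3,4-dichlorophenyl)amino changes the result at all.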